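From Cyanomethyl to 2-Chlorobenzyl: Expected Cytotoxicity

This account rests on a few compounds, and the source may have more. Where it says the series, first, only, none or still open, it means among the compounds named here.

Of the compounds shown here, three sharing one core have been tested in an ADME assay on MT4 cells (Homo sapiens) for cytotoxicity, read by MTT assay, with a stated time of 5 days; on this read-out higher numbers stand for lower toxicity in this test and lower numbers for higher toxicity in this test. Compound 1 `O=C1N(Cc2ccccc2)c2cccn2S(=O)(=O)N1Cc1cccc(F)c1` gives only a limit, > 288000 nM. Compound 2 `N#Cc1ccccc1CN1C(=O)N(Cc2cccc(F)c2)S(=O)(=O)n2cccc21` likewise gives only a limit, > 305000 nM. Among the compounds with values here, compound 3 `N#CCN1C(=O)N(Cc2cccc(F)c2)S(=O)(=O)n2cccc21` gives the one actual number, 172000 nM, so it stands alone as the measured point among the three. Compound 4 `O=C1N(Cc2ccccc2Cl)c2cccn2S(=O)(=O)N1Cc1cccc(F)c1` differs from compound 3 by 2-chlorophenyl in place of cyano on a saturated chain carbon bound to an amide-type nitrogen in a ring. The measured steps that bear on this run the other way: an at least 1.6-fold lower number from compound 1 to compound 3 (0.22 log units; that floor lies within the scatter) and an at least 1.7-fold lower number from compound 2 to compound 3 (0.24 log units; that floor lies within the scatter), both floors that lie within the scatter. Reversing that kind of change, a number at least as high as before is expected for compound 4, an estimated 1.7-fold higher number from compound 3 to compound 4 (0.24 log units; within the scatter) in this assay. Compound 4 is therefore expected to give 300000 nM, within 150000 nM to 600000 nM, quite possibly again only a limit.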

Compound 4, half-maximal cytotoxic concentration: 231000 nM
Estimate against measurement, compound 4: 1.3-fold (0.11 log units) above, and the stated range covers the measured number.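

In this assay, within the data shown here, 2-chlorophenyl in place of cyano at this position gives a 1.3-fold higher number from compound 3 to compound 4 (0.13 log units; within the scatter), the first comparison here between two actual numbers rather than a number and a limit. Chloro in place of cyano on the aromatic carbon gives an at least 1.3-fold lower number from compound 2 to compound 4 (0.12 log units; that floor lies within the scatter), and chloro in place of hydrogen gives an at least 1.2-fold lower number from compound 1 to compound 4 (0.09 log units; that floor lies within the scatter). From the compounds shown here alone, both of these steps are only floors, so their true sizes stay unknown.

Going by these compounds, whether an amine, a carboxylic acid or a longer chain on this saturated chain carbon would move the number beyond the scatter remains open.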